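Moving a methyl group on the aniline of compound 1

This account rests on a few compounds, and the source may have more. Where it says the series, first, only, none or still open, it means among the compounds named here.

Measured so far in a functional assay on A549 cells (Homo sapiens) for antiproliferative activity, read by spectrophotometry, with a stated time of 2 days; on this read-out higher numbers stand for weaker inhibition of growth and lower numbers for stronger inhibition of growth:
- compound 1 `Cc1ccc(Nc2ncc(C(F)(F)F)c(N3Cc4cccc(N(C)S(C)(=O)=O)c4C3)n2)cc1C`: > 30000 nM (a limit)
- compound 2 `COc1cc(N2CCN(C(C)=O)CC2)ccc1Nc1ncc(C(F)(F)F)c(N2Cc3cccc(N(C)S(C)(=O)=O)c3C2)n1`: 3300 nM

Compound 1 stands at the end of the measurable range of this assay. Its entry of > 30000 nM is a limit and not a number. Of the two measured compounds, only compound 2 gives an actual number, 3300 nM.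

The next compound is compound 3 `Cc1cc(C)cc(Nc2ncc(C(F)(F)F)c(N3Cc4cccc(N(C)S(C)(=O)=O)c4C3)n2)c1`, which has the same atoms as compound 1, joined differently. The change lies in one place: 3,5-dimethylphenyl in place of 3,4-dimethylphenyl on a nitrogen on an aromatic ring. In words, 3,5-dimethylphenyl stands in place of 3,4-dimethylphenyl on a nitrogen on an aromatic ring.

For the measured compounds named here, no measured pair shows what this kind of change does in this assay, so the expectation rests on the starting point alone. Compound 1 gives > 30000 nM, and that limit is the only anchor for the expectation. No step beyond the scatter is expected, and compound 3 may also be reported only as a limit. The estimated step is a number no higher from compound 1 to compound 3 (the limit leaves the size open). For compound 3 the expected value is 30000 nM, with an estimated range of 12000 nM to 60000 nM.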

Compound 3, concentration for 50% growth inhibition: > 30000 nM
Compound 3 gave a limit, no number; the forecaster's own chance of this, stated with the estimate: 65%; the middle value sits exactly at the limit.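

In this assay, compound 3 ends at a limit, as compound 1 does, and neither gives a number, so no step between compound 1 and compound 3 can be read: the limit of > 30000 nM in this assay, at which 2 of the 3 values shown sit.

The compounds shown leave open whether 3,5-dimethylphenyl and 3,4-dimethylphenyl differ at all in this assay.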